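Butyrate ester on the tertiary alcohol of compound 2

The compounds below may be only part of what the source reports. "The series", "measured", "known", "first", "only" and "open" are said of these compounds alone.

Among the compounds with values here, compound 2 `OC1C=C[C@]2(O)CCO[C@@H]2C1` gives 40.8 ug/mL in a functional assay on P388 cells (Mus musculus) for cytotoxicity (a higher number here means a weaker inhibitor, a lower number a stronger inhibitor), the only plain number among the two values shown. Compound 1 `O=C1C=C[C@]2(OC(=O)c3cccc(Cl)c3)CCO[C@@H]2C1` gives < 0.1 ug/mL in this assay, a limit of the assay and not a number; it sits at the limit of < 0.1 ug/mL in this assay, at which 1 of the 2 values shown sits. Compound 3 `CCCC(=O)O[C@]12C=CC(O)C[C@H]1OCC2` differs from compound 2 in one place: propylcarbonyl in place of hydrogen on an oxygen on a saturated carbon. No step between measured compounds is shown, so the size of this change rests on expectation alone. Compound 3 is estimated at 5 ug/mL, between 0.5 ug/mL and 30 ug/mL. The step of an 8.2-fold lower number from compound 2 to compound 3 (0.91 log units; beyond the scatter) is expected to go beyond the scatter toward stronger inhibition.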

Compound 3, half-maximal inhibitory concentration: > 100 ug/mL
Compound 3 was reported as a limit (the forecaster's own chance of this, stated with the estimate: 10%); middle value at least 20-fold (1.30 log units) from the limit.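

In this assay, propylcarbonyl in place of hydrogen on an oxygen on a saturated carbon gives an at least 2.4-fold higher number from compound 2 to compound 3 (0.38 log units; beyond the scatter). Within the data shown here, this is the first step measured at this position, and it runs toward weaker inhibition. Compound 3 stands at a limit of the assay and not at a number, so the step's true size stays unfixed: the limit of > 100 ug/mL in this assay, at which 1 of the 3 values shown sits.

As far as these compounds go, whether an acetyl group, a longer acyl chain or a methyl ether on this oxygen would behave the same remains open. Compound 1 differs from compound 2 in more than one place, so the part played by its ester stays unresolved.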